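This account rests on a few compounds, and the source may have more. Where it says the series, first, only, none or still open, it means among the compounds named here.

Compound 1 `CC(C)n1ncc2c(C(=O)NC3CCCC3)cccc21` gives 19400 nM. Compound 2 `CC(C)n1ncc2c(C(=O)NCc3cn(-c4ccccc4)nn3)cccc21` gives 26000 nM. Compound 3 `CC(C)n1ncc2c(C(=O)NCc3cn(-c4ccc(I)cc4)nn3)cccc21` gives only a limit, > 40000 nM.

In a functional assay on PC-3 cells (Homo sapiens) for inhibition, read by MTT assay, with a stated time of 72 h (on this read-out lower numbers stand for stronger inhibition and higher numbers for weaker inhibition), compound 3 stands at the limit of the assay, with no number of its own; this is the limit of > 40000 nM in this assay, at which 1 of the 3 values shown sits. Compound 4 `CC(C)n1ncc2c(C(=O)NCc3cn(-c4cccc(F)c4)nn3)cccc21` differs from compound 3 in one place: 3-fluorophenyl in place of 4-iodophenyl on an aromatic nitrogen. Among the compounds with values here, the one measured step that bears on this change is an at least 1.5-fold higher number from compound 2 to compound 3 (0.18 log units; that floor lies within the scatter), where a halogen on that phenyl ring moved the number up to the limit. Removing the iodine and placing a fluorine elsewhere on the ring is therefore expected to bring compound 4 back toward the value of compound 2, a step of an at least 1.3-fold lower number from compound 3 to compound 4 (0.12 log units; that floor lies within the scatter). Compound 4 is expected at 30000 nM, within 14000 nM to 60000 nM.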

Compound 4, half-maximal inhibitory concentration: 36100 nM
Estimate against measurement, compound 4: 1.2-fold (0.08 log units) below; the range from low to high includes it.
By their numbers in this assay, from the lowest: compounds 1, 2 and 4 (each within the scatter of the next). At a limit, above all of these: compound 3.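

In this assay the step of a 1.4-fold higher number from compound 2 to compound 4 (0.14 log units; within the scatter) shows that a fluoro group on the phenyl ring gives no separation from the unsubstituted ring. The step of an at least 1.1-fold lower number from compound 3 to compound 4 (0.04 log units; that floor lies within the scatter) likewise gives no separation between 3-fluorophenyl and 4-iodophenyl on the aromatic nitrogen. Compound 3 still has no number of its own, only a limit: the limit of > 40000 nM in this assay, at which 1 of the 4 values shown sits.

On these data alone, whether an amine or a carboxylic acid on the phenyl ring, or a longer chain in its place, would move the number beyond the scatter stays open.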